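A few compounds are considered here, and "the series" means these few. Any claim that something is new, unique, unknown or untested is made for them only; others in the source may bear on it.

Compound 1 `CCOC(=O)c1cc2ccc(OCCCCCn3cc(CNC(=O)CCCCC4CCSS4)nn3)cc2oc1=O`: 34.4%
Compound 2 `COc1ccc(-c2cc3ccc(OCCCCCn4cc(CNC(=O)CCCCC5CCSS5)nn4)cc3oc2=O)cc1OC`: 38.5%

Among the measured compounds shown here, in a functional assay on PC-12 cells (Rattus norvegicus) for cytotoxicity, read by MTT assay, with stated times of 3 h and 2 h, tested at 0.1 uM (on this read-out lower numbers stand for a weaker effect and higher numbers for a stronger effect at the one concentration tested), compound 2 gives 38.5%, the higher of the two numbers so far, while compound 1 gives 34.4%; the difference a number 4.1 percentage points higher from compound 1 to compound 2 (within the scatter) is within the scatter, so the two are not distinguished. Compound 3 `O=C(CCCCC1CCSS1)NCc1cn(CCCCCOc2ccc3cc(-c4ccc(Br)cc4)c(=O)oc3c2)nn1` differs from compound 2 in one place: 4-bromophenyl in place of 3,4-dimethoxyphenyl on an aromatic carbon. For the measured compounds named here, the only measured step that bears on this is a number 4.1 percentage points higher from compound 1 to compound 2 (within the scatter), where one group on an aromatic carbon of the shared core was swapped for another and the read-out hardly moved. Since a change at the same kind of position left this assay unchanged beyond the scatter, the expectation for compound 3 is no step beyond the scatter either, in either direction, described as a number 0.5 percentage points lower from compound 2 to compound 3 (within the scatter). Compound 3 is therefore estimated at 38%, with a range from 26% to 50%.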

Compound 3, a percentage reported as activity, at one concentration (the size of the read-out at that concentration, not a potency): 41.8%
Estimate against measurement, compound 3: 3.8 percentage points below, within the range that was stated.
By their numbers in this assay, from the lowest: compounds 1, 2 and 3 (each within the scatter of the next).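

Putting 4-bromophenyl in place of 3,4-dimethoxyphenyl gives a number 3.3 percentage points higher from compound 2 to compound 3 (within the scatter) in this assay, and putting it in place of ethoxycarbonyl gives a number 7.4 percentage points higher from compound 1 to compound 3 (within the scatter). This aromatic carbon has now carried three different groups, including a ring with 0 hydrogen-bond acceptors in place of one with 2, and none of the steps among them lies beyond the scatter. Nothing measured alongside these numbers explains why they stay so close.

As far as these compounds go, whether an amine or a carboxylic acid on this aromatic carbon would move the read-out beyond the scatter remains open. All three compounds also share everything outside this position, so they cannot show what a change elsewhere, such as a longer chain linking the two ends of the molecule, would do.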